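The source may hold more compounds than are shown below. What is called first, only, known or untested is meant among the compounds shown, and "the series" means these compounds.

In a functional assay on A20 cells (Mus musculus) for inhibition, with stated times of 1 h, 16 h and 24 h (on this read-out lower numbers stand for stronger inhibition and higher numbers for weaker inhibition), the measured compounds gave these values:

compound 1 `N#CC1(NC(=O)[C@@H]2C[C@@H](S(=O)(=O)c3ccccc3)C[C@H]2C(=O)N2CCCCC2)CC1`: 5 nM
compound 2 `N#CC1(NC(=O)[C@@H]2C[C@@H](S(=O)(=O)c3ccccc3)C[C@H]2C(=O)N2CCC(O)CC2)CC1`: 371 nM
compound 3 `N#CC1(NC(=O)[C@@H]2C[C@@H](S(=O)(=O)c3ccccc3)C[C@H]2C(=O)N2CCC2)CC1`: 44 nM

Compound 3 differs from compound 1 in one place, (azetidin-1-yl in place of piperidin-1-yl on a carbonyl carbon), and this ring change gave an 8.8-fold higher number from compound 1 to compound 3 (0.94 log units; beyond the scatter). Compound 2 also differs from compound 1 in one place, (hydroxy in place of hydrogen on a saturated ring carbon), and that change gave a 74-fold higher number from compound 1 to compound 2 (1.87 log units; beyond the scatter), a large loss.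

Compound 4 `N#CC1(NC(=O)[C@@H]2C[C@@H](S(=O)(=O)c3ccccc3)C[C@H]2C(=O)N2CC(O)C2)CC1` has not yet been measured. It differs from compound 3 by hydroxy in place of hydrogen on a saturated ring carbon. Among the measured compounds shown here, this is the same kind of change as the one from compound 1 to compound 2, but the surroundings differ: in compound 2 the hydroxy sits on a six-membered non-aromatic ring with 1 nitrogen, three ring bonds from the ring nitrogen, whereas in compound 4 it sits on a four-membered non-aromatic ring with 1 nitrogen, two ring bonds from the ring nitrogen.

For the measured compounds named here, because the only measured example of this kind of change is a 74-fold higher number from compound 1 to compound 2 (1.87 log units; beyond the scatter), a loss is expected for compound 4 as well, though its size on the smaller ring is uncertain; the expected step is a 20-fold higher number from compound 3 to compound 4 (1.31 log units; beyond the scatter). Compound 4 is therefore estimated at 900 nM in this assay, most likely between 200 nM and 4000 nM.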

Compound 4, half-maximal inhibitory concentration: 572 nM
Estimate against measurement, compound 4: 1.6-fold (0.20 log units) above, within the range that was stated.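

In this assay the hydroxy group again goes with weaker inhibition on the smaller ring, with a 13-fold higher number from compound 3 to compound 4 (1.11 log units; beyond the scatter), and the whole change in the group on the carbonyl gives a 110-fold higher number from compound 1 to compound 4 (2.06 log units; beyond the scatter), so the direction of the change carries from one core to the other. Its size does not carry over: the same change on two cores in this assay, a 74-fold higher number (1.87 log units; beyond the scatter) from compound 1 to compound 2 and a 13-fold higher number (1.11 log units; beyond the scatter) from compound 3 to compound 4, 5.7-fold (0.76 log units) apart, beyond the scatter of two such steps

Once the hydroxy is present on both rings, the two compounds cannot be told apart, with a 1.5-fold higher number from compound 2 to compound 4 (0.19 log units; within the scatter), but two pairs show neither why the steps differ in size nor how the change would behave on a ring of another size.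

The compounds shown leave open whether the loss is tied to hydroxy itself or would also appear with a methoxy group, a fluorine atom or an amine on the same saturated ring carbon. They also leave open whether any such group could keep inhibition close to that of compound 1 at 5 nM.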